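This account rests on a few compounds, and the source may have more. Where it says the series, first, only, none or still open, it means among the compounds named here.

Compounds measured in a functional assay on ONS-76 cells (Homo sapiens) for cytotoxicity, read by MTT assay, with a stated time of 72 h; on this read-out lower numbers stand for stronger inhibition and higher numbers for weaker inhibition:
- Compound 1 `COc1cc(N(C)C(=O)N(C)c2ccc(F)cc2)cc(OC)c1OC` gives a limit of the assay and not a number, >= 125000 nM.
- Compound 2 `COc1cc(N(C)C(=O)N(C)c2cccc([N+](=O)[O-])c2)cc(OC)c1OC` gives a limit of the assay and not a number, >= 125000 nM.
- Compound 3 `COc1cc(N(C)C(=O)N(C)c2ccc([N+](=O)[O-])cc2)cc(OC)c1OC` gives a limit of the assay and not a number, >= 125000 nM.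

Compound 3 therefore stands at the same limit as every other value shown, which is the line (the limit of >= 125000 nM in this assay, at which 3 of the 3 values shown sit). Within the series the steps a step that the two limits leave unreadable from compound 1 to compound 2, a step that the two limits leave unreadable from compound 1 to compound 3 and a step that the two limits leave unreadable from compound 2 to compound 3 all lie between two limits, so none of them can be read as a size or a direction.

Compound 4 `COc1cc(N(C)C(=O)N(C)c2cccc(F)c2)cc(OC)c1OC` is not yet measured. It differs from compound 3 in one place: 3-fluorophenyl in place of 4-nitrophenyl on an amide-type nitrogen. The measured steps that bear on this change are the three between compounds 1, 2 and 3, and each is hidden by the limit; a swap of a halogen for a nitro group, or a move of the nitro group, has never given a readable value here. The step that the limit leaves unreadable from compound 3 to compound 4 is therefore expected to stay unreadable as well. Compound 4 is estimated at 150000 nM, with a range of 50000 nM to 500000 nM, and most likely the assay will again report only its limit.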

Compound 4, half-maximal inhibitory concentration: >= 125000 nM
Compound 4 was reported as a limit; the forecaster's own chance of this, stated with the estimate: 85%; the middle value lies beyond the limit too.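

In this assay compound 4 gives only a limit of the assay, >= 125000 nM. For the compounds shown here, no step from compound 1, compound 2 or compound 3 to compound 4 can be read: the limit of >= 125000 nM in this assay, at which 4 of the 4 values shown sit. The compounds shown leave open whether swapping or moving the fluoro and nitro groups changes cytotoxicity at all.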